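From chloro to cyano on the shared core

The compounds below may be only part of what the source reports. "The series", "measured", "known", "first", "only" and "open" are said of these compounds alone.

Among the compounds with values here, in an ADME assay on L6 cells (Rattus norvegicus) for cytotoxicity, read by fluorescence and resazurin assay, with a stated time of 72 h (on this read-out lower numbers stand for higher toxicity in this test and higher numbers for lower toxicity in this test), compound 2 `Clc1ccc(-c2c[nH]cc2C(c2ccc(Cl)cc2Cl)n2ccnc2)cc1` gives 9610 nM, the lower of the two numbers so far, while compound 1 `CC(C)(C)c1ccc(-c2c[nH]cc2C(c2ccc(Cl)cc2Cl)n2ccnc2)cc1` gives 22900 nM. Compound 3 `N#Cc1ccc(-c2c[nH]cc2C(c2ccc(Cl)cc2Cl)n2ccnc2)cc1` has cyano in place of chloro on an aromatic carbon, para to a large group: cyano in place of chloro on an aromatic carbon. Within the data shown here, only one measured step bears on this change, a 2.4-fold lower number from compound 1 to compound 2 (0.38 log units; beyond the scatter), and it involves a different swap at that place. A modest rise or smaller in this assay is therefore expected, with the direction uncertain. The expected step is a 1.4-fold higher number from compound 2 to compound 3 (0.13 log units; within the scatter). For compound 3 the estimated value is 13000 nM, within a range from 5500 nM to 30000 nM.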

Compound 3, half-maximal cytotoxic concentration: 15000 nM
The estimate for compound 3 lay 1.2-fold (0.06 log units) below the measured number, and the stated range covers the measured number.
By their numbers in this assay, from the lowest: compounds 2, 3 and 1 (each within the scatter of the next, the first and the last beyond it).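

In this assay, cyano on this aromatic carbon sits within the scatter of both earlier groups: against chloro (a 1.6-fold higher number from compound 2 to compound 3 (0.19 log units; within the scatter)) and against tert-butyl (a 1.5-fold lower number from compound 1 to compound 3 (0.18 log units; within the scatter)). Within the data shown here, the only earlier step at this place went beyond the scatter, whereas neither step to cyano does, so compound 3 cannot be ranked apart from compound 1 or compound 2. No measurement shown here explains this result.

Still open, from the compounds shown here alone, is whether an amine or a carboxylic acid on this carbon would shift the number beyond the scatter from compound 2.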